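Trifluoromethyl on the pendant phenyl of compound 2

This account rests on a few compounds, and the source may have more. Where it says the series, first, only, none or still open, it means among the compounds named here.

Compound 2 `O=C(Nc1cc2cc[nH]c(=O)c2cc1Cl)C1CNCC1c1ccccc1` gives 6 nM in an assay on isolated protein for inhibition of Rho-associated protein kinase 2 (Homo sapiens), read by a luciferase reporter (a higher number here means a weaker inhibitor, a lower number a stronger inhibitor), and compound 1 `Cc1cccc(C2CNCC2C(=O)Nc2cc3cc[nH]c(=O)c3cc2Cl)c1` gives 5 nM in this assay, so the two stand together within the scatter. Compound 3 `O=C(Nc1cc2cc[nH]c(=O)c2cc1Cl)C1CNCC1c1cccc(C(F)(F)F)c1` carries trifluoromethyl in place of hydrogen on an aromatic carbon. Within the data shown here, the one step that bears on it, a 1.2-fold higher number from compound 1 to compound 2 (0.08 log units; within the scatter), shows that a methyl on an aromatic carbon of this ring made no difference beyond the scatter; a step of no size beyond the scatter is therefore expected in this assay for compound 3. Compound 3 is estimated at 6 nM, between 2.5 nM and 15 nM, which corresponds to an expected step of no change at the digits printed from compound 2 to compound 3 (within the scatter).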

Compound 3, half-maximal inhibitory concentration: 4 nM
Beside the measured number, compound 3's estimate is 1.5-fold (0.18 log units) above it; measured number inside the range.
By their numbers in this assay, from the lowest: compounds 3, 1 and 2 (each within the scatter of the next).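

In this assay, the step from hydrogen to trifluoromethyl on this aromatic carbon, meta to a large group, stays within the scatter (a 1.5-fold lower number from compound 2 to compound 3 (0.18 log units; within the scatter)), and so does the step from methyl to trifluoromethyl (a 1.3-fold lower number from compound 1 to compound 3 (0.10 log units; within the scatter)). Hydrogen, methyl and trifluoromethyl therefore cannot be told apart at this position, which now accepts a group with fluorine as well as a plain alkyl group without a readable change. No independent measurement bears on this result. From the compounds shown here alone, whether an amine or a carboxylic acid here would hold the number stays open, as does the effect of trifluoromethyl at other carbons of this ring.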